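A Butoxy Group Enters Compound 2

A few compounds are considered here, and "the series" means these few. Any claim that something is new, unique, unknown or untested is made for them only; others in the source may bear on it.

Within the data shown here, compound 2 `O=C(NN1CCOCC1)C1=NN(c2ccc(Cl)cc2Cl)C(c2ccccc2)C1` gives 31.9% in a functional assay on the whole organism (strain Zucker) for inhibition, with Rattus norvegicus as the target, with a stated time of 4 h, at a dose of 10 mg/kg by the oral route (a lower number here means less inhibition, a higher number more inhibition at the dose given (going by the name of the read-out)), the higher of the two numbers known, while compound 1 `O=C(NN1CCOCC1)C1=NN(c2ccccc2)C(c2ccccc2)C1` gives 11.9%. Among the measured compounds shown here, the single measured step, a number 20 percentage points higher from compound 1 to compound 2 (beyond the scatter), concerns the group on the amine nitrogen in the ring and so says nothing about the change now at hand. Compound 3 `CCCCOc1ccc(C2CC(C(=O)NN3CCOCC3)=NN2c2ccc(Cl)cc2Cl)cc1` differs from compound 2 by butoxy in place of hydrogen on an aromatic carbon. For the measured compounds named here, with no measured step speaking to this change, the step of a number 3.1 percentage points higher from compound 2 to compound 3 (within the scatter) is expected to stay within the scatter. Compound 3 is therefore estimated at 35%, in a range from 15% to 55%.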

Compound 3, a percentage reported as inhibition, in the whole organism at one dose (the size of the read-out at that dose, not a potency): 18.1%
The estimate for compound 3 lay 16.9 percentage points above the measured number, within the range that was stated.
By their numbers in this assay, from the lowest: compounds 1 and 3 (each within the scatter of the next); then compound 2.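

Among these compounds, the first reading at this position, on an aromatic carbon para to a large group, shows that the change from phenyl to 4-butoxyphenyl is not neutral: in this assay it gives a number 13.8 percentage points lower from compound 2 to compound 3 (beyond the scatter) at the dose given. The earlier step concerned only the group on the amine nitrogen and gave no view of this carbon. Nothing at hand gives a reason for this drop.

From the compounds shown here alone, whether methoxy, an amine or a carboxylic acid on the same carbon would also lower the number remains open. So does whether butoxy has the same effect when phenyl takes the place of 2,4-dichlorophenyl on the amine nitrogen.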